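Swapping the Amide Arm for a Furyl Ketone

This account rests on a few compounds, and the source may have more. Where it says the series, first, only, none or still open, it means among the compounds named here.

Compound 1, `O=C(NCc1ccccc1)C(=O)c1cn(Cc2ccccc2)c2ccccc12`: > 10000 nM
Compound 2, `O=C(Nc1ccccc1)C(=O)c1cn(Cc2ccccc2)c2ccccc12`: > 10000 nM

In an assay on CHO cells for displacement of a labelled ligand from adenosine receptor A1 (Homo sapiens), with a stated time of 180 min (on this read-out higher numbers stand for weaker inhibition and lower numbers for stronger inhibition), compound 1 gives only a limit, > 10000 nM. Compound 2 likewise gives only a limit in this assay, > 10000 nM. The step that the two limits leave unreadable from compound 1 to compound 2 therefore cannot be read, as the limit of > 10000 nM in this assay, at which 2 of the 2 values shown sit, shows. Compound 3, `O=C(C(=O)c1cn(Cc2ccccc2)c2ccccc12)c1ccco1`, differs from compound 2 by furan-2-yl in place of anilino on a carbonyl carbon. Among the measured compounds shown here, no measured step in this assay bears on this change, so the expectation rests only on where compound 2 stands. Compound 3 is expected at 15000 nM, within 3000 nM to 80000 nM. The expected step is a step that the limit leaves unreadable from compound 2 to compound 3, most likely again ending at a limit.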

Compound 3, inhibition constant: 343 nM
For compound 3 the middle estimate is 44-fold (1.64 log units) above the measured one; measured number outside the range, below it.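

Among the compounds shown here, on the carbonyl carbon, furan-2-yl gives the first number in this assay that is not a limit: there is an at least 29-fold lower number from compound 2 to compound 3 (1.46 log units; beyond the scatter), and also an at least 29-fold lower number from compound 1 to compound 3 (1.46 log units; beyond the scatter). Lower numbers mean stronger inhibition, so changing this arm alone can turn a compound without a readable value into one with a measured value. The step from compound 1 to compound 2 cannot be read: the limit of > 10000 nM in this assay, at which 2 of the 3 values shown sit.

The compounds shown leave open whether the gain depends on the furan oxygen or on losing the amide hydrogen. A thiophen-2-yl group or an N-methylanilino group at this carbon would help separate the two.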